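The compounds below may be only part of what the source reports. "The series", "measured", "known", "first", "only" and "open" are said of these compounds alone.

Measured so far:

Compound 1 `CCNC1=NC(=O)[C@H]([C@H](C)c2c[nH]c3ccccc23)S1` — 10 ug/mL
Compound 2 `CNC1=NC(=O)C(Cc2c[nH]c3ccccc23)S1` — 30 ug/mL

Compound 1 gives the lowest of the two numbers in an ADME assay on BHK cells (Mesocricetus auratus) for cytotoxicity; on this read-out higher numbers stand for lower toxicity in this test and lower numbers for higher toxicity in this test. Its nearest neighbour on this read-out is compound 2, whose number is higher by a margin beyond the usual scatter; the two differ in more than one place, so nothing is drawn from that pair beyond what the two values show.

The step followed here leads from compound 1 to compound 3 `C[C@H](c1c[nH]c2ccccc12)[C@@H]1SC(NCCO)=NC1=O`, which is still to be measured in this assay. The change is hydroxy in place of hydrogen on a saturated chain carbon, two bonds along the chain from an amine nitrogen.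

Among the compounds with values here, no measured pair in this set isolates this change, so the expected size of the step rests on the two values alone and on the nature of the change. The working expectation is a small rise in the minimum cytotoxic concentration for compound 3, a 1.8-fold higher number from compound 1 to compound 3 (0.26 log units; within the scatter), of a size that could well sit within the scatter. For compound 3 the estimate in this assay is 18 ug/mL, with a range from 7 ug/mL to 50 ug/mL.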

Compound 3, minimum cytotoxic concentration: 100 ug/mL
Compound 3: the middle estimate sits 5.6-fold (0.74 log units) below what was measured; measured number outside the range, above it.
By their numbers in this assay, from the lowest: compound 1; then compound 2; then compound 3.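

In this assay the change from ethylamino to (2-hydroxyethyl)amino gives a 10-fold higher number from compound 1 to compound 3 (1.00 log units; beyond the scatter) on this read-out, so the end of this chain is not a silent position in this test. Within the data shown here, compound 3 stands at 100 ug/mL with the rest of compound 1 left as it was, which ties this rise in the minimum cytotoxic concentration, and so the lower toxicity in this test, to the one change of hydrogen to hydroxy on a saturated chain carbon, two bonds along the chain from an amine nitrogen. Nothing available accounts for the size of this step, which rests on a single pair of compounds.

As far as these compounds go, whether the rise belongs to the hydroxy group itself or would also appear with a methoxy group, a carboxylic acid, an amine or a longer chain ending in hydroxy remains open. Also open, from the compounds shown here alone, is whether the same change would give a step of similar size on the methylamino compound 2, which differs from compound 1 in more than one place and so offers no direct reading here.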